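Swapping the Phenyl Imidazolidinone for a Pyrimidinyl Pyrrolidinone

The source may report more compounds than this note shows. Statements on the series, on what has been measured and on what is new or still open speak of the compounds shown alone.

Measured so far:
- compound 1 `O=C1NC(c2ccccc2)CN1c1cnn2c1CN(C(=O)Nc1cc(F)c(F)c(F)c1)C(C1CC1)C2`: 38500 nM
- compound 2 `C[C@H]1Cn2ncc(N3CC(c4ccccc4)CC3=O)c2CN1C(=S)Nc1cc(F)c(F)c(F)c1`: > 2000 nM
- compound 3 `C[C@H]1Cn2ncc(N3CC(c4ccccc4)CC3=O)c2CN1C(=O)NCc1cc(F)c(F)c(F)c1`: > 2000 nM

Going by the values given here, in a toxicity assay on HepG2 2.2.15 cells (Homo sapiens) for cytotoxicity, read by CellTiter-Glo (a lower number here means that less compound is tolerated, a higher number that more compound is tolerated), compound 1 gives 38500 nM, the only plain number among the three values shown. For compound 2 the result is a limit of the assay, > 2000 nM, not a number. The same holds for compound 3, whose result is the limit > 2000 nM. Among the compounds with values here, these two limits are summarised as the limit of > 2000 nM in this assay, at which 2 of the 3 values shown sit, so no measured step between two compounds can be drawn from them, and nothing more can be said of how compound 2 or compound 3 compares with compound 1.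

Compound 4 `O=C1CC(c2ncccn2)CN1c1cnn2c1CN(C(=O)Nc1cc(F)c(F)c(F)c1)C(C1CC1)C2` is not yet measured. It differs from compound 1 in one place: 2-oxo-4-(pyrimidin-2-yl)pyrrolidin-1-yl in place of 2-oxo-4-phenylimidazolidin-1-yl on an aromatic carbon. Within the data shown here, no measured step of this kind is available, so the expectation rests on compound 1 alone. In this assay the step of a 1.0-fold higher number from compound 1 to compound 4 (0.02 log units; within the scatter) is expected to stay within the usual scatter, with no clear direction. Compound 4 is therefore expected to give about 40000 nM, most likely between 15000 nM and 100000 nM.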

Compound 4, half-maximal cytotoxic concentration: > 200000 nM
Compound 4: only a limit was reported; the forecaster's own chance of this, stated with the estimate: 25%; at least 5.0-fold (0.69 log units) between middle value and limit.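

In this assay, putting 2-oxo-4-(pyrimidin-2-yl)pyrrolidin-1-yl in place of 2-oxo-4-phenylimidazolidin-1-yl on the aromatic carbon gives an at least 5.1-fold higher number from compound 1 to compound 4 (0.71 log units; beyond the scatter), the only step among these compounds that can be read; the steps involving compound 2 and compound 3 cannot. It shows that the tolerated amount of compound responds to what sits at this position on the shared core, and that this exchange moves it towards more compound being tolerated. The result for compound 4 is a limit and not a number: the limit of > 200000 nM in this assay, at which 1 of the 4 values shown sits.

The exchange alters both the five-membered ring and the six-membered aromatic ring at once, so the compounds shown cannot tell which of the two carries the step. On these data alone, how a pyridin-2-yl group would behave in place of the pyrimidin-2-yl group also remains open.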